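Cytotoxicity notes on the aromatic-nitrogen substituent series

This account rests on a few compounds, and the source may have more. Where it says the series, first, only, none or still open, it means among the compounds named here.

Measured so far in an ADME assay on C8166 cells (Homo sapiens) for cytotoxicity, read by MTT assay; a lower number here means that less compound is tolerated, a higher number that more compound is tolerated:
- compound 1, `CC(C)n1cc(C(=O)O)c(=O)c2c(O)c(Cc3cccc(Cl)c3F)ccc21`: 26500 nM
- compound 2, `CCC(C)n1cc(C(=O)O)c(=O)c2c(O)c(Cc3cccc(Cl)c3F)ccc21`: 30700 nM
- compound 3, `O=C(O)c1cn(C2CC2)c2ccc(Cc3cccc(Cl)c3F)c(O)c2c1=O`: 39100 nM

Compound 3 gives the highest of the three numbers in this assay, but its nearest neighbour is compound 2, a 1.3-fold higher number from compound 2 to compound 3 (0.11 log units; within the scatter), and its furthest is compound 1, a 1.5-fold higher number from compound 1 to compound 3 (0.17 log units; within the scatter), so all three lie within the scatter of one another and no ordering can be read from them.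

Compound 4, `CC(C)[C@@H](CO)n1cc(C(=O)O)c(=O)c2c(O)c(Cc3cccc(Cl)c3F)ccc21`, is the next member. It differs from compound 3 at the aromatic nitrogen: 1-(hydroxymethyl)-2-methylpropyl in place of cyclopropyl on an aromatic nitrogen

Among the measured compounds shown here, the steps that bear on this change are the two earlier exchanges of the group on the aromatic nitrogen, a 1.5-fold higher number from compound 1 to compound 3 (0.17 log units; within the scatter) and a 1.3-fold higher number from compound 2 to compound 3 (0.11 log units; within the scatter), together with the chain extension a 1.2-fold higher number from compound 1 to compound 2 (0.06 log units; within the scatter). None of them moves the readout beyond the scatter. For the measured compounds named here, the group entering in compound 4 is larger than any tried so far and brings a hydroxyl, for which the three measured compounds give no precedent, so the expectation rests on the observed insensitivity of this assay to the group on this nitrogen.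

Compound 4 is therefore expected to stay close to compound 3, with a step of a 1.2-fold lower number from compound 3 to compound 4 (0.07 log units; within the scatter), and an estimated value of 33000 nM in the range 15000 nM to 70000 nM in this assay.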

Compound 4, half-maximal cytotoxic concentration: 125000 nM
Estimate against measurement, compound 4: 3.8-fold (0.58 log units) below; the whole stated range lies below it.
By their numbers in this assay, from the lowest: compounds 1, 2 and 3 (each within the scatter of the next); then compound 4.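

In this assay, the group on the aromatic nitrogen proves able to move the number beyond the scatter: 1-(hydroxymethyl)-2-methylpropyl in place of cyclopropyl gives the largest departure yet seen at this position (a 3.2-fold higher number from compound 3 to compound 4 (0.50 log units; beyond the scatter)), and the same holds against sec-butyl (a 4.1-fold higher number from compound 2 to compound 4 (0.61 log units; beyond the scatter)) and isopropyl (a 4.7-fold higher number from compound 1 to compound 4 (0.67 log units; beyond the scatter)). The earlier insensitivity therefore holds only among cyclopropyl, isopropyl and sec-butyl, and it does not extend to this acyclic group, the only one of the four on this nitrogen that carries a hydroxyl. Nothing at hand explains the higher number, and the change of group alone does not settle which of its features goes with it.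

On these data alone, the hydroxyl, the larger chain and the defined stereocentre all enter together in compound 4, so their separate contributions remain open, and the same chain without the hydroxyl, with a methyl ether or an amine in its place, or with the opposite configuration at the stereocentre would separate them. As far as these compounds go, whether a longer hydroxyalkyl chain on this nitrogen would go further in the same direction also remains open.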